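Two Branched Alkyl Groups on the Same Core

The source may report more compounds than this note shows. Statements on the series, on what has been measured and on what is new or still open speak of the compounds shown alone.

Measured so far:
Compound 1, `CCC(CC)/N=c1\c(O)c(O)\c1=N/Cc1ccc(C#N)cc1`: in a functional assay for inhibition, with Rattus norvegicus as the target (on this read-out higher numbers stand for weaker inhibition and lower numbers for stronger inhibition), compound 1 gives 1300 nM.
Compound 2, `N#Cc1ccc(CNc2c(NC3CCCC3)c(=O)c2=O)cc1`: in this assay compound 2 gives 9400 nM.

Of these two numbers, compound 1 has the lower one, and the gap to compound 2 lies beyond the usual scatter, so compound 1 is the stronger inhibitor of the pair. Among the compounds with values here, no single-point step between the two measured compounds is available, since they differ in more than one place.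

Compound 3, `C[C@@H](/N=c1\c(O)c(O)\c1=N/Cc1ccc(C#N)cc1)C(C)(C)C`, differs from compound 1 in one place: 1,2,2-trimethylpropyl in place of pentan-3-yl on a double-bonded nitrogen. Both groups are branched alkyl chains without rings, donors or acceptors, so little change is expected from this swap. The step of a 1.2-fold lower number from compound 1 to compound 3 (0.07 log units; within the scatter) is expected to stay within the scatter, with no clear direction. For compound 3 the estimate is 1100 nM, with a range from 400 nM to 3200 nM.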

Compound 3, half-maximal inhibitory concentration: 270 nM
Beside the measured number, compound 3's estimate is 4.1-fold (0.61 log units) above it; measured number below the stated range.
By their numbers in this assay, from the lowest: compound 3; then compound 1; then compound 2.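

Swapping one branched alkyl group for another on this double-bonded nitrogen is not a silent change: in this assay the swap gives a 4.8-fold lower number from compound 1 to compound 3 (0.68 log units; beyond the scatter), a modest step. Neither group has a ring, a hydrogen-bond donor or acceptor, or a net charge, so this position responds even to a change among purely carbon groups. The entering group differs by one more carbon and one defined stereocentre, and nothing measured here shows which of these differences, if either, accounts for the step.

The compounds shown leave open whether the opposite arrangement at that stereocentre would give a similar number. They also leave open how this position would respond to a longer chain, or to a chain carrying an amine or a carboxylic acid.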